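Trimming the amide group of compound 2

A few compounds are considered here, and "the series" means these few. Any claim that something is new, unique, unknown or untested is made for them only; others in the source may bear on it.

In a functional assay on KETR3 cells (Homo sapiens) for inhibition, read by MTT assay, with a stated time of 120 h (a higher number here means a weaker inhibitor, a lower number a stronger inhibitor), compound 2 `CC(NC(=O)C#Cc1ccc(NC(=O)Nc2ccc(Cl)c(C(F)(F)F)c2)cc1)c1ccccc1` gives 21400 nM and compound 1 `CC(NC(=O)C#Cc1ccc(NC(=O)Nc2cc(C(F)(F)F)ccc2Cl)cc1)c1ccccc1` gives 23200 nM, two numbers within the scatter of each other. Compound 3 `C/C(=C\C(=O)N1CC(C)OC(C)C1)c1ccc(NC(=O)Nc2ccc(Cl)c(C(F)(F)F)c2)cc1`, which has no 1-phenylethyl group, is reported only as a limit, > 50000 nM. Compound 4 `CNC(=O)C#Cc1ccc(NC(=O)Nc2ccc(Cl)c(C(F)(F)F)c2)cc1` differs from compound 2 in one place: methyl in place of 1-phenylethyl on an amide-type nitrogen. Among the compounds with values here, the one measured step, a 1.1-fold lower number from compound 1 to compound 2 (0.04 log units; within the scatter), swaps a different group, so it gives no direct guide to this change. Within the data shown here, compound 3, at its limit of > 50000 nM, is the only indirect guide. A small move toward weaker inhibition is therefore expected, a 1.6-fold higher number from compound 2 to compound 4 (0.21 log units; within the scatter). Compound 4 is estimated at 35000 nM, with an expected range of 12000 nM to 70000 nM.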

Compound 4, half-maximal inhibitory concentration: 24700 nM
For compound 4 the middle estimate is 1.4-fold (0.15 log units) above the measured one, and the stated range covers the measured number.
By their numbers in this assay, from the lowest: compounds 2, 1 and 4 (each within the scatter of the next). At a limit, above all of these: compound 3.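

On this amide-type nitrogen, 1-phenylethyl can be replaced by methyl, losing its aromatic ring, with a 1.2-fold higher number from compound 2 to compound 4 (0.06 log units; within the scatter) in this assay. The large group therefore adds nothing measurable to inhibition here, and the smaller compound 4 holds the same level as compound 2. No measurement shown here explains why this change leaves the number flat.

Going by these compounds, whether any group at this position can move the number beyond the scatter remains open. A longer chain, an amine or a carboxylic acid in place of methyl would test that.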